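Acetyl in Place of Hydrogen on Two Related Cores

This account rests on a few compounds, and the source may have more. Where it says the series, first, only, none or still open, it means among the compounds named here.

Three compounds have been measured in an assay on thoracic aorta for binding affinity to Endothelin-1 receptor (Rattus norvegicus); a lower number here means a stronger inhibitor, a higher number a weaker inhibitor:

Compound 1, `Cc1noc(NS(=O)(=O)c2ccc(N)c3ccccc23)c1C`, gives 3500 nM.
Compound 2, `CC(=O)Nc1ccc(S(=O)(=O)Nc2onc(C)c2C)c2ccccc12`, gives 3400 nM.
Compound 3, `Cc1noc(NS(=O)(=O)c2ccc3ccc(N)cc3c2)c1C`, gives 10000 nM.

Compound 1 and compound 2 share one core, and compound 2 carries acetyl in place of hydrogen on a nitrogen on an aromatic ring. In this assay this gave a 1.0-fold lower number from compound 1 to compound 2 (0.01 log units; within the scatter), a step within the usual scatter, so the two values show no order between them. Compound 3 is built from the same atoms as compound 1, joined differently; the difference between the two cores is not broken down here. In this assay compound 3 gives the highest of the three numbers, beyond the scatter from compound 1 and from compound 2.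

Compound 4, `CC(=O)Nc1ccc2ccc(S(=O)(=O)Nc3onc(C)c3C)cc2c1`, has not yet been measured. Relative to compound 3 it carries acetyl in place of hydrogen on a nitrogen on an aromatic ring, the same change as from compound 1 to compound 2, at a place described in the same words. The expected step is no change at the digits printed from compound 3 to compound 4 (within the scatter), resting on compound 1 and compound 2, where the same change gave a 1.0-fold lower number from compound 1 to compound 2 (0.01 log units; within the scatter). Compound 4 is therefore estimated at 10000 nM, expected to fall between 4000 nM and 25000 nM.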

Compound 4, half-maximal inhibitory concentration: 42000 nM
Compound 4: middle estimate off by 4.2-fold (0.62 log units), on the low side; measured number outside the range, above it.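

In this assay, acetyl in place of hydrogen on a nitrogen on an aromatic ring gave a 4.2-fold higher number from compound 3 to compound 4 (0.62 log units; beyond the scatter), whereas on the core of compound 1 the same change left the number within the scatter, so the step did not carry over from one core to the other: the same change on two cores in this assay, a 1.0-fold lower number (0.01 log units; within the scatter) from compound 1 to compound 2 and a 4.2-fold higher number (0.62 log units; beyond the scatter) from compound 3 to compound 4, 4.3-fold (0.64 log units) apart, beyond the scatter of two such steps. The change from amino to acetamido therefore cannot be treated as a fixed step in this series, since its size differed between these two cores. The two pairs do not show which feature of the cores sets the steps apart, and they give no rule for predicting the step on a third core.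

The compounds shown leave open whether a longer acyl chain, such as propionyl, would follow acetyl on each core. They also leave open whether a methyl or a methanesulfonyl group on that same nitrogen would separate the two cores in the same way.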